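The source may hold more compounds than are shown below. What is called first, only, known or untested is meant among the compounds shown, and "the series" means these compounds.

Measured so far:

Compound 1, `COc1cc(C=C(C(=O)/C=C/c2cccc(OC)c2OC)C(=O)/C=C/c2cccc(OC)c2OC)ccc1O`, gives 430 nM.
Compound 2, `COc1cccc(/C=C/C(=O)C(=Cc2ccc(O)c(F)c2)C(=O)/C=C/c2cccc(OC)c2OC)c1OC`, gives 330 nM.
Compound 3, `COc1ccc(/C=C/C(=O)C(=Cc2ccc(O)c(OC)c2)C(=O)/C=C/c2ccc(OC)cc2OC)c(OC)c1`, gives 1520 nM.

All three values come from a functional assay on SW480 cells (Homo sapiens) for antiproliferative activity, read by sulforhodamine B assay, with a stated time of 48 h; on this read-out higher numbers stand for weaker inhibition and lower numbers for stronger inhibition. Compound 1 and compound 2 share one core and differ only in one place: fluoro in place of methoxy on an aromatic carbon. That change produced a 1.3-fold lower number from compound 1 to compound 2 (0.11 log units; within the scatter), so on this pair the swap leaves the read-out essentially where it was.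

Compound 3 carries a different core from compound 1; the two have the same atoms joined differently, and the difference between the two cores is not broken down here. In this assay the number for compound 3 is the highest of the three, and its gaps to compound 1 and to compound 2 both lie beyond the usual scatter, so the core of compound 3 reads as the weaker of the two.

Compound 4, `COc1ccc(/C=C/C(=O)C(=Cc2ccc(O)c(F)c2)C(=O)/C=C/c2ccc(OC)cc2OC)c(OC)c1`, is not yet measured. It stands to compound 3 as compound 2 stands to compound 1: fluoro in place of methoxy on an aromatic carbon. The surroundings of the change are the same in both pairs, so this is the same change made on the second core. The expectation is therefore that the step of a 1.3-fold lower number from compound 3 to compound 4 (0.10 log units; within the scatter) will be small, in line with a 1.3-fold lower number from compound 1 to compound 2 (0.11 log units; within the scatter), because compound 1 at 430 nM and compound 2 at 330 nM sit within the scatter of each other. Starting from compound 3 at 1520 nM, compound 4 is expected to give about 1200 nM, with a likely range from 550 nM to 2800 nM. Whether the change behaves the same on the second core is what the measurement will show.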

Compound 4, half-maximal inhibitory concentration: 3350 nM
Compound 4: the middle estimate sits 2.8-fold (0.45 log units) below what was measured; measured number above the stated range.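

On the core of compound 3, replacing 4-hydroxy-3-methoxyphenyl with 3-fluoro-4-hydroxyphenyl gives a 2.2-fold higher number from compound 3 to compound 4 (0.34 log units; beyond the scatter) in this assay, a shift that the pair on the core of compound 1 did not show. The same change therefore does not carry unaltered from one core to the other in this series, and the result on one core cannot simply be transferred to the other: the same change on two cores in this assay, a 1.3-fold lower number (0.11 log units; within the scatter) from compound 1 to compound 2 and a 2.2-fold higher number (0.34 log units; beyond the scatter) from compound 3 to compound 4, 2.9-fold (0.46 log units) apart, beyond the scatter of two such steps. This does not show why the two cores part, how the change would behave on any further core, or whether the gap would hold in other cells, since it rests on one pair for each core in one assay.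

Still open, going by these compounds, is whether a chloro or a methyl group in place of methoxy on the same aromatic carbon would follow the fluoro result on each core, which would indicate whether the divergence is tied to fluoro or extends to other replacements of methoxy. Also open, on these data alone, is whether an amine in place of the hydroxy group would keep the two cores apart or bring their steps together.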